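From acetoxy to acetamido on a cyclohexyl ring

The compounds below may be only part of what the source reports. "The series", "measured", "known", "first", "only" and "open" are said of these compounds alone.

Measured so far in an ADME assay on cells (Hepatocyte, Mus musculus) for metabolic stability; on this read-out lower numbers stand for a shorter-lived compound and higher numbers for a longer-lived compound
Compound 1 `CS(=O)(=O)NC1CCC(CN2CCN(c3cc(=O)c4cc(C(F)(F)F)cc([N+](=O)[O-])c4s3)CC2)CC1` gives > 1.55 h
Compound 2 `O=C(NC1CCC(CN2CCN(c3cc(=O)c4cc(C(F)(F)F)cc([N+](=O)[O-])c4s3)CC2)CC1)c1ccccc1` gives > 1.55 h
Compound 3 `CC(=O)OC1CCC(CN2CCN(c3cc(=O)c4cc(C(F)(F)F)cc([N+](=O)[O-])c4s3)CC2)CC1` gives < 0.15 h

Compound 3 stands at the limit of < 0.15 h in this assay, at which 1 of the 3 values shown sits, and that value is a limit, not a number. Compound 1 and compound 2 sit at the limit of > 1.55 h in this assay, at which 2 of the 3 values shown sit, and that value is also a limit, not a number.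

Compound 4 `CC(=O)NC1CCC(CN2CCN(c3cc(=O)c4cc(C(F)(F)F)cc([N+](=O)[O-])c4s3)CC2)CC1` has not yet been measured. It differs from compound 3 in one place, with acetamido in place of acetoxy on a saturated ring carbon.

Going by the values given here, two measured steps bear on this change, an at least 10-fold lower number from compound 1 to compound 3 (1.01 log units; beyond the scatter) and an at least 10-fold lower number from compound 2 to compound 3 (1.01 log units; beyond the scatter), and both are large. In each, acetoxy is the group that enters. Acetamido most resembles the benzamido of compound 2, so the reverse of an at least 10-fold lower number from compound 2 to compound 3 (1.01 log units; beyond the scatter) is expected in this assay, a large rise towards the upper limit. The expected step is an at least 10-fold higher number from compound 3 to compound 4 (1.02 log units; beyond the scatter) and it points upward. Compound 4 is estimated at 1.6 h, with an expected range from 0.6 h to 4 h, and it may be reported only as a limit.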

Compound 4, half-life: > 1.55 h
Compound 4 gave a limit, no number; the forecaster's own chance of this, stated with the estimate: 60%; the middle value lies beyond the limit too.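

In this assay, keeping the acetyl part and exchanging only the oxygen of acetoxy for the nitrogen of acetamido gives an at least 10-fold higher number from compound 3 to compound 4 (1.01 log units; beyond the scatter), so the short half-life of compound 3 does not depend on losing a methylsulfonyl or benzoyl group. The value of compound 4 is a limit, not a number, and it sits with compound 1 and compound 2: the limit of > 1.55 h in this assay, at which 3 of the 4 values shown sit. The steps linking compound 4 to compound 1 and compound 2 cannot be read, and these three compounds cannot be ranked against one another.

Going by these compounds, how far each of the three lies past the limit stays open. Also open, on these data alone, is whether a free amine, a methyl ether or a carbamate on this saturated ring carbon would give a short or a long half-life in this assay.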